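Swapping Iodine for a Furan Ring on a Weak Inhibitor

A few compounds are considered here, and "the series" means these few. Any claim that something is new, unique, unknown or untested is made for them only; others in the source may bear on it.

Compound 2 `CNc1ncnc2c1c(I)cn2[C@@H]1O[C@H](CO)[C@@H](O)[C@H]1O` has been tested in a functional assay on HeLa S3 cells (Homo sapiens) for antiproliferative activity, read by XTT assay, with a stated time of 72 h; a higher number here means a weaker inhibitor, a lower number a stronger inhibitor. Compound 2 gives > 20000 nM, which is a limit of the assay rather than a number. Compound 2 thus stands at the limit of > 20000 nM in this assay, at which 2 of the 3 values shown sit. Compound 3 `COc1ncnc2c1c(I)cn2[C@@H]1O[C@H](CO)[C@@H](O)[C@H]1O` gives 14300 nM. Among the compounds with values here, the one measured step, an at least 1.3-fold lower number from compound 2 to compound 3 (0.14 log units; that floor lies within the scatter), changes only the group on the other aromatic carbon and does not touch the iodo. Compound 1 `Cc1ncnc2c1c(-c1ccoc1)cn2[C@@H]1O[C@H](CO)[C@@H](O)[C@H]1O` carries the furan-3-yl and gives > 20000 nM, again a limit of the assay. Compound 4 `CNc1ncnc2c1c(-c1ccoc1)cn2[C@@H]1O[C@H](CO)[C@@H](O)[C@H]1O` differs from compound 2 by furan-3-yl in place of iodo on an aromatic carbon. Within the data shown here, no measured step covers this change, so no step beyond the scatter is expected. Compound 4 is expected to give 25000 nM, between 12000 nM and 60000 nM, an estimated step that the limit leaves unreadable from compound 2 to compound 4.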

Compound 4, half-maximal inhibitory concentration: > 20000 nM
Compound 4 gave a limit, no number; the forecaster's own chance of this, stated with the estimate: 75%; the middle value does not contradict the limit.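

In this assay compound 4 gives > 20000 nM, a limit of the assay. Within the data shown here, compound 1 and compound 2 also stand at limits, so no step from either to compound 4 can be read. As far as these compounds go, what furan-3-yl in place of iodo does to the activity stays open.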